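Working notes on a small cytotoxicity series

This account rests on a few compounds, and the source may have more. Where it says the series, first, only, none or still open, it means among the compounds named here.

compound 1 `CCc1c(C(=O)OC)[n+]([O-])c2ccccc2[n+]1[O-]` — 47 ug/mL
compound 2 `CCc1c(C(=O)OC)[n+]([O-])c2cc(Cl)ccc2[n+]1[O-]` — > 10 ug/mL (a limit)
compound 3 `CCOC(=O)COC(=O)c1c(CC)[n+]([O-])c2ccc(Cl)cc2[n+]1[O-]` — 1.89 ug/mL

In an ADME assay on Vero cells (Chlorocebus sabaeus) for cytotoxicity (a higher number here means a weaker inhibitor, a lower number a stronger inhibitor), compound 1 gives 47 ug/mL. For compound 2 only a limit of the assay is known, > 10 ug/mL. Compound 2 differs from compound 1 by chloro in place of hydrogen on an aromatic carbon; the step is a step that the limit leaves unreadable from compound 1 to compound 2 because of the limit of > 10 ug/mL in this assay, at which 1 of the 3 values shown sits. Compound 3 gives 1.89 ug/mL, the lower of the two read numbers; from compound 2 the step is an at least 5.2-fold lower number from compound 2 to compound 3 (0.72 log units; beyond the scatter). The difference between the cores of compound 1 and compound 3 is not broken down here.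

Compound 4 `CCOC(=O)COC(=O)c1c(CC)[n+]([O-])c2cc(Cl)c(Cl)cc2[n+]1[O-]` is not yet measured; it differs from compound 3 by chloro in place of hydrogen on an aromatic carbon, the same kind of change as from compound 1 to compound 2, though here the place is ortho to a chloro group. The earlier step is unreadable, so the expectation rests on compound 3 alone. Compound 4 is expected to give 1.5 ug/mL, an expected step of a 1.3-fold lower number from compound 3 to compound 4 (0.10 log units; within the scatter).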

Compound 4, half-maximal inhibitory concentration: 1.22 ug/mL
The estimate for compound 4 lay 1.2-fold (0.09 log units) above the measured number; the measured number falls inside the stated range.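

In this assay, the step for chloro in place of hydrogen on an aromatic carbon, here ortho to a chloro group, is a 1.5-fold lower number from compound 3 to compound 4 (0.19 log units; within the scatter), so on the core of compound 3 this change shows no difference beyond the scatter. The same kind of change on the core of compound 1 cannot be read, because compound 2 carries only a limit: the limit of > 10 ug/mL in this assay, at which 1 of the 4 values shown sits. With a single readable step, the series does not show whether the change carries from one core to another.

The compounds shown leave open whether an amine or a carboxylic acid in place of the added chloro would give a step beyond the scatter. They also leave open how a longer chain on the ester would read.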